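This account rests on a few compounds, and the source may have more. Where it says the series, first, only, none or still open, it means among the compounds named here.

Working notes on the series. Compound 1 `COc1cccc(N2C(=O)COc3ccc(-c4cnc(Cl)c(NS(=O)(=O)c5ccc(F)cc5)c4)cc32)c1` carries a 3-methoxyphenyl on the amide-type nitrogen of the shared core. In a functional assay on MCF7 cells (Homo sapiens) for antiproliferative activity, read by MTT assay, with a stated time of 72 h (on this read-out lower numbers stand for stronger inhibition and higher numbers for weaker inhibition), compound 1 gives > 40000 nM, which is a limit of the assay and not a number. Compound 2 `O=C1COc2ccc(-c3cnc4ccccc4c3)cc2N1`, with hydrogen on the same ring nitrogen and a different aromatic group attached to the core, is also reported only as a limit: in this assay compound 2 gives > 40000 nM. Both values shown therefore sit at the limit of > 40000 nM in this assay, at which 2 of the 2 values shown sit, and compound 1 stands there together with compound 2, with no ordering between them.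

Compound 3 `O=C1COc2ccc(-c3cnc(Cl)c(NS(=O)(=O)c4ccc(F)cc4)c3)cc2N1` is the next compound to be measured in this assay. It differs from compound 1 by hydrogen in place of 3-methoxyphenyl on an amide-type nitrogen in a ring. For the measured compounds named here, no step between measured compounds is available to size this change; the only pointer is that compound 2, which also bears hydrogen on the amide-type nitrogen, gives > 40000 nM. The step from compound 1 to compound 3 is expected to be a number no higher from compound 1 to compound 3 (the limit leaves the size open), that is, none beyond the scatter. Compound 3 is accordingly estimated at 40000 nM, in a range from 15000 nM to 100000 nM, most likely again reported as a limit.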

Compound 3, half-maximal inhibitory concentration: > 40000 nM
Compound 3: a limit, no number; the forecaster's own chance of this, stated with the estimate: 75%; the middle value lies on the limit itself.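

The step between compound 1 and compound 3 cannot be read, as both values are limits of the assay and not numbers: the limit of > 40000 nM in this assay, at which 3 of the 3 values shown sit. The compounds shown leave open how hydrogen and 3-methoxyphenyl on the amide-type nitrogen compare in this assay once a measurable value exists.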